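The compounds below may be only part of what the source reports. "The series", "measured", "known", "first", "only" and "open" are said of these compounds alone.

Measured so far in an assay on CHO cells for displacement of a labelled ligand from prostaglandin E2 receptor EP3 subtype (Mus musculus), read by scintillation counting, with a stated time of 60 min; on this read-out higher numbers stand for weaker inhibition and lower numbers for stronger inhibition:
- compound 1 `O=C(O)CCCSCCN1C(=O)OC[C@@H]1/C=C/[C@@H](O)Cc1ccccc1`; compound 1 gives 6400 nM
- compound 2 `CCCc1cccc(C[C@H](O)/C=C/[C@H]2CCC(=S)N2CCCCCCC(=O)O)c1`; compound 2 gives 2000 nM
- compound 3 `O=C(O)CCCSCCN1C(=O)OC[C@@H]1/C=C/[C@@H](O)Cc1cccc(C(F)(F)F)c1`; compound 3 gives 1600 nM

Compound 3 has the lowest of the three numbers shown. Its gap to compound 2 is within the scatter, so no order between these two is claimed. Against compound 1 the single-point step is a 4.0-fold lower number from compound 1 to compound 3 (0.60 log units; beyond the scatter), trifluoromethyl in place of hydrogen on an aromatic carbon.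

Compound 4 `O=C(O)CCCSCCN1C(=O)OC[C@@H]1/C=C/[C@@H](O)Cc1cccc(-c2ccccc2)c1` differs from compound 3 in one place: phenyl in place of trifluoromethyl on an aromatic carbon. Within the data shown here, only one measured step bears on this position, a 4.0-fold lower number from compound 1 to compound 3 (0.60 log units; beyond the scatter), and it shows that placing a group on this aromatic carbon lowered the number in this assay. Among the measured compounds shown here, no measured pair exchanges trifluoromethyl for phenyl, so the direction of this particular swap is open. A step of modest size or none beyond the scatter is expected, leaning toward a lower number. Compound 4 is therefore estimated at 1000 nM, with a range from 300 nM to 4000 nM. The expected step is a 1.6-fold lower number from compound 3 to compound 4 (0.20 log units; within the scatter).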

Compound 4, inhibition constant: > 10000 nM
Compound 4: no number, only a limit; the forecaster's own chance of this, stated with the estimate: 5%; middle value at least 10-fold (1.00 log units) from the limit.
By their numbers in this assay, from the lowest: compounds 3 and 2 (each within the scatter of the next); then compound 1. At a limit, above all of these: compound 4.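

Compound 4 has no number in this assay, only a limit: the limit of > 10000 nM in this assay, at which 1 of the 4 values shown sits. Trifluoromethyl and phenyl are not interchangeable on this aromatic carbon: the swap gives an at least 6.2-fold higher number from compound 3 to compound 4 (0.79 log units; beyond the scatter), so the gain seen in a 4.0-fold lower number from compound 1 to compound 3 (0.60 log units; beyond the scatter) does not extend to every group placed here. Against hydrogen at the same carbon, the step is an at least 1.5-fold higher number from compound 1 to compound 4 (0.19 log units; that floor lies within the scatter), so phenyl cannot be said to do worse than hydrogen.

Going by these compounds, whether a smaller group on this carbon, such as a methoxy group or a chlorine atom, would keep the number of compound 3 stays open, as does how far compound 4 lies beyond its limit. Also open, on these data alone, is whether phenyl on this carbon would act the same way on the core of compound 2.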